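Ester to Methyl Amide: Expected Plasma Half-Life

The source may report more compounds than this note shows. Statements on the series, on what has been measured and on what is new or still open speak of the compounds shown alone.

Compound 1 `COCCOC(=O)c1cc(N)c(Nc2ccc(C#N)cc2)cc1Oc1c(C)cc(/C=C/C#N)cc1C` carries a 2-methoxyethoxy group on the carbonyl carbon of the shared core. Among the measured compounds shown here, in an ADME assay on a cell-free system (plasma, Homo sapiens) for metabolic stability, read by LC-MS, tested at 10 ug/mL (a lower number here means that the compound disappears faster, a higher number that the compound lasts longer), compound 1 gives 62 h, one of only two numbers measured so far; its sole neighbour, compound 2 `CCNC(=O)c1cc(N)c(Nc2ccc(C#N)cc2)cc1Oc1c(C)cc(/C=C/C#N)cc1C`, gives 91 h in the same assay, and the one measured step, a 1.5-fold higher number from compound 1 to compound 2 (0.17 log units; within the scatter), stays within the scatter. That step places ethylamino in place of 2-methoxyethoxy on the carbonyl carbon.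

Compound 3 `CNC(=O)c1cc(N)c(Nc2ccc(C#N)cc2)cc1Oc1c(C)cc(/C=C/C#N)cc1C` is the unmeasured member: methylamino in place of 2-methoxyethoxy on a carbonyl carbon. The step from compound 1 to compound 2 is the closest reference, since there too an amino substituent entered in place of 2-methoxyethoxy on a carbonyl carbon whose other neighbour is an aromatic carbon, and the number moved only within the scatter. Compound 3 is therefore expected to lie near compound 2, with a 1.5-fold higher number from compound 1 to compound 3 (0.16 log units; within the scatter) expected to be small, if anything upward, and not clearly beyond the scatter. The estimate for compound 3 in this assay is 90 h, with a range from 50 h to 160 h.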

Compound 3, half-life: 72 h
Compound 3: middle estimate off by 1.3-fold (0.10 log units), on the high side; low and high end bracket the measured number.
By their numbers in this assay, from the lowest: compounds 1, 3 and 2 (each within the scatter of the next).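

In this assay, a second amide on this carbonyl carbon gives no separation from the ester: the step is a 1.2-fold higher number from compound 1 to compound 3 (0.06 log units; within the scatter) and so, like the step to the ethylamino compound, it does not pass the scatter. The earlier compounds shown here could not show what a change within the amino substituent itself does, and here the step is a 1.3-fold lower number from compound 2 to compound 3 (0.10 log units; within the scatter) for hydrogen in place of methyl on a saturated chain carbon bound to an amide-type nitrogen, so ethylamino and methylamino cannot be told apart at this position. Nothing measured here gives a reason for this, and the three half-lives can only be read as lying together.

Still open, going by these compounds, is whether this flat picture holds for a carboxylic acid on the same carbonyl carbon, for a dimethylamino group, which has no amide hydrogen, or for a longer chain such as propylamino. On these data alone, all three compounds also share the same core, so whether the swap of 2-methoxyethoxy for an amino substituent behaves alike on another core remains open as well.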